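The source may hold more compounds than are shown below. What is called first, only, known or untested is meant among the compounds shown, and "the series" means these compounds.

Of the compounds shown here, three have so far been measured in a physicochemical assay for lipophilicity, measured as octanol-water partition; on this read-out higher numbers stand for higher lipophilicity and lower numbers for lower lipophilicity. Compound 1, `Cc1cc(OCC(O)CO)cc(C)c1Cl`, gives 2.42 and compound 3, `Cc1cc(Cl)c(OCCCO)c(Cl)c1`, gives 3.36. Compound 2, `Cc1ccccc1OCC(C)O`, gives 2.14, the lowest of the three numbers; it lies within the usual scatter of compound 1 and beyond the scatter of compound 3. Compound 4, `Cc1cccc(Cl)c1OCC(C)O`, has not yet been measured and differs from compound 2 by chloro in place of hydrogen on an aromatic carbon. Among the measured compounds shown here, no two measured compounds differ in just one place, so no measured step shows what this change does. A rise in this assay beyond the scatter is nevertheless expected, because compound 3 bearing chloro groups gives 3.36. The expected step is a number 0.66 log units higher from compound 2 to compound 4 (beyond the scatter). Compound 4 is thus estimated at 2.8, in the range 2.5 to 3.2.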

Compound 4, partition coefficient: 2.73
Compound 4: middle estimate off by 0.07 log units, on the high side, within the range that was stated.
By their numbers in this assay, from the lowest: compounds 2 and 1 (each within the scatter of the next); then compound 4; then compound 3.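

Among the compounds shown here, the step (a number 0.59 log units higher from compound 2 to compound 4 (beyond the scatter)) is the first direct reading in this assay of chloro in place of hydrogen on an aromatic carbon, here ortho to a group of 5 heavy atoms and meta to a methyl group. For the compounds shown here, it comes from a pair differing in one place, so the size of this change no longer rests on compounds differing in several places. Nothing available explains why the step has this size. As far as these compounds go, whether fluoro, methoxy or an amine at this place would give a similar step stays open. So does whether chloro gives the same step on another aromatic carbon.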